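Three Thiocarbamates Measured, a Dimethylamino Analogue Awaited

A few compounds are considered here, and "the series" means these few. Any claim that something is new, unique, unknown or untested is made for them only; others in the source may bear on it.

Measured in an ADME assay on MT4 cells (Homo sapiens) for cytotoxicity, read by MTT assay; on this read-out higher numbers stand for lower toxicity in this test and lower numbers for higher toxicity in this test:
Compound 1 `FC(F)(F)c1ccc(NC(=S)OCCc2ccccn2)cc1`: 50000 nM
Compound 2 `N#Cc1ccc(NC(=S)OCCc2ccccn2)cc1`: 45000 nM
Compound 3 `CC(=O)c1ccc(NC(=S)OCCc2ccccn2)cc1`: >= 100000 nM

For compound 3 the value is a limit of the assay rather than a number (the limit of >= 100000 nM in this assay, at which 1 of the 3 values shown sits). Compounds 1 and 2 sit close together (a 1.1-fold lower number from compound 1 to compound 2 (0.05 log units; within the scatter)), while an at least 2.0-fold higher number from compound 1 to compound 3 (0.30 log units; that floor lies within the scatter) and an at least 2.2-fold higher number from compound 2 to compound 3 (0.34 log units; beyond the scatter) show that exchanging the varying group shifts the number only modestly. Compound 4 `CN(C)c1ccc(NC(=S)OCCc2ccccn2)cc1` differs from compound 3 by dimethylamino in place of acetyl on an aromatic carbon. Among the measured compounds shown here, no measured step involves dimethylamino, so the expectation rests on how little those earlier swaps moved the number, and the estimated step is an at least 1.2-fold lower number from compound 3 to compound 4 (0.09 log units; that floor lies within the scatter), not beyond the scatter. Compound 4 is therefore expected to give about 80000 nM in this assay, within 35000 nM to 180000 nM, with a fair chance that only a limit is reported again.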

Compound 4, half-maximal cytotoxic concentration: 60000 nM
The estimate for compound 4 lay 1.3-fold (0.12 log units) above the measured number; the range from low to high includes it.
By their numbers in this assay, from the lowest: compounds 2, 1 and 4 (each within the scatter of the next). At a limit, above all of these: compound 3.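

Dimethylamino is the first group at this place to carry nitrogen directly on the aromatic carbon, yet in this assay the number stays within the scatter of the other two exact values: a 1.2-fold higher number from compound 1 to compound 4 (0.08 log units; within the scatter) and a 1.3-fold higher number from compound 2 to compound 4 (0.12 log units; within the scatter). Putting dimethylamino in place of acetyl gives an at least 1.6-fold lower number from compound 3 to compound 4 (0.22 log units; that floor lies within the scatter), so acetyl may stand apart, although that floor does not show it. Compound 3 remains a limit of the assay, not a number: the limit of >= 100000 nM in this assay, at which 1 of the 4 values shown sits.

From the compounds shown here alone, how far compound 3 truly lies from the others stays open. So does the effect of a primary amine, a carboxylic acid or a longer chain at this place.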